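Compound 1 to compound 4: octyl for 4-chlorophenyl

This account rests on a few compounds, and the source may have more. Where it says the series, first, only, none or still open, it means among the compounds named here.

Among the measured compounds shown here, in a functional assay on MDA-MB-231 cells (Homo sapiens) for cytotoxicity, read by sulforhodamine B assay, with a stated time of 72 h (on this read-out lower numbers stand for stronger inhibition of growth and higher numbers for weaker inhibition of growth), compound 1 `O=C(Nc1ccccc1O)C1CCc2ccccc2N1C(=O)c1ccc(Cl)cc1` gives 19600 nM as the highest of three numbers so far, against compound 2 `O=C(Nc1ccccc1C(F)(F)F)C1CCc2ccccc2N1C(=O)c1cccc(Cl)c1` at 288 nM and compound 3 `O=C(Nc1ccccc1C(F)(F)F)C1CCc2ccccc2N1C(=O)c1ccc(Cl)cc1` at 533 nM in the same read-out.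

Compound 4 `CCCCCCCCC(=O)N1c2ccccc2CCC1C(=O)Nc1ccccc1O` keeps the hydroxy group of compound 1 and carries octyl in place of 4-chlorophenyl on a carbonyl carbon.

The large measured step, trifluoromethyl in place of hydroxy, reads a 37-fold lower number from compound 1 to compound 3 (1.57 log units; beyond the scatter) and lies at another place, so it says little here. For the measured compounds named here, at the carbonyl carbon the only measured step is a 1.9-fold higher number from compound 2 to compound 3 (0.27 log units; within the scatter) and it joins two chlorophenyl groups. Going by the values given here, no measured compound has an open chain at this place, so the data give no direction, and no step beyond the scatter is expected, though with wide uncertainty.

For compound 4 the estimated value is 15000 nM with an expected range from 4000 nM to 50000 nM in this series. The expected change on this estimate is a 1.3-fold lower number from compound 1 to compound 4 (0.12 log units; within the scatter) in this assay for now.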

Compound 4, concentration for 50% growth inhibition: 54300 nM
Compound 4: the middle estimate sits 3.6-fold (0.56 log units) below what was measured; measured number outside the range, above it.
By their numbers in this assay, from the lowest: compounds 2 and 3 (each within the scatter of the next); then compound 1; then compound 4.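

Among the compounds shown here, at the carbonyl carbon whose other neighbour is the amide-type nitrogen in a ring, the change from 4-chlorophenyl to octyl gives in this assay a 2.8-fold higher number from compound 1 to compound 4 (0.44 log units; beyond the scatter) and is the first step at this place to lie beyond the scatter. The earlier step here only joined two chlorophenyl groups, so this result shows that the number at this place responds to the group carried, though modestly. An open chain with no ring still leaves a measurable number with the hydroxy group kept, and nothing measured here accounts for the step.

Open, going by these compounds, is whether a shorter chain such as butyl, or a saturated ring such as cyclohexyl, would follow octyl or 4-chlorophenyl at this place. Also open, on these data alone, is whether octyl shifts the number to the same extent when trifluoromethyl replaces hydroxy.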